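This account rests on a few compounds, and the source may have more. Where it says the series, first, only, none or still open, it means among the compounds named here.

For the measured compounds named here, compound 2 `Cc1cccc(NC(=O)N/N=C2\C(=O)Nc3ccccc32)c1` is one of two compounds so far tested in an ADME assay on RD cells (Homo sapiens) for cytotoxicity (on this read-out lower numbers stand for higher toxicity in this test and higher numbers for lower toxicity in this test), and its value is a limit of the test rather than a number. In this assay compound 2 reports a limit of > 25000 nM. Compound 1 `O=C(N/N=C1\C(=O)Nc2ccccc21)Nc1ccccc1` carries hydrogen where compound 2 carries methyl. In this assay compound 1 likewise reports a limit of > 25000 nM. The step that the two limits leave unreadable from compound 1 to compound 2 is therefore unreadable, both values sitting at the limit of > 25000 nM in this assay, at which 2 of the 2 values shown sit. Compound 3 `COc1cccc(NC(=O)N/N=C2\C(=O)Nc3ccccc32)c1` differs from compound 2 by methoxy in place of methyl on an aromatic carbon. Going by the values given here, the single measured step, a step that the two limits leave unreadable from compound 1 to compound 2, gives no readable size, and no measured step bears on a methoxy-for-methyl exchange. With both values at the limit, the expected step that the limit leaves unreadable from compound 2 to compound 3 is none beyond the scatter, most probably another limit. Compound 3 is estimated to give about 30000 nM in this assay, between 15000 nM and 80000 nM.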

Compound 3, half-maximal cytotoxic concentration: > 25000 nM
Compound 3: only a limit was reported; the forecaster's own chance of this, stated with the estimate: 85%; the middle value lies beyond the limit too.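

In this assay compound 3 gives a limit, > 25000 nM, so no step from compound 1 or compound 2 to compound 3 can be read: the limit of > 25000 nM in this assay, at which 3 of the 3 values shown sit.

The compounds shown leave open whether hydrogen, methyl or methoxy on this aromatic carbon makes any difference in this assay.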